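Lengthening the fluorinated side group of compound 2

This account rests on a few compounds, and the source may have more. Where it says the series, first, only, none or still open, it means among the compounds named here.

- compound 1 `CC(O)c1nc([C@@H](O)[C@H](O)[C@H](O)CO)c[nH]1`: 10300 ng.h/mL
- compound 2 `CC(F)(F)c1nc([C@@H](O)[C@H](O)[C@H](O)CO)c[nH]1`: 1190 ng.h/mL

In an ADME assay on the whole organism (plasma, strain 129/SvEvBrd x C57BL/6) for pharmacokinetics, with Mus musculus as the target, at a dose of 10 mg/kg by the oral route (on this read-out lower numbers stand for lower exposure and higher numbers for higher exposure at the dose given), compound 2 gives 1190 ng.h/mL, the lower of the two numbers. Compound 3 `OC[C@@H](O)[C@@H](O)[C@H](O)c1c[nH]c(C(F)(F)C(F)(F)F)n1` brings trifluoromethyl in place of methyl on a saturated chain carbon bound to an aromatic carbon and two fluorine atoms. Going by the values given here, only one measured step bears on this, an 8.7-fold lower number from compound 1 to compound 2 (0.94 log units; beyond the scatter), and it exchanged 1-hydroxyethyl rather than methyl, so it is a loose guide. The expected step is a 1.5-fold lower number from compound 2 to compound 3 (0.17 log units; within the scatter), a slight drop estimated to stay within the scatter. The estimate for compound 3 is 800 ng.h/mL, with an expected range from 250 ng.h/mL to 2600 ng.h/mL.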

Compound 3, area under the concentration-time curve: 3060 ng.h/mL
Estimate against measurement, compound 3: 3.8-fold (0.58 log units) below; the whole stated range lies below it.
By their numbers in this assay, from the lowest: compound 2; then compound 3; then compound 1.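

Trifluoromethyl in place of methyl on a saturated chain carbon bound to an aromatic carbon and two fluorine atoms gives, in this assay, a 2.6-fold higher number from compound 2 to compound 3 (0.41 log units; beyond the scatter). This position therefore responds to a change within the fluorinated side group, and here the longer group raises the number rather than lowering it. Nothing available explains the rise. Going by these compounds, whether a longer fluorinated chain would raise the number further remains open, as one step sets no trend. So does the effect of an amine at this position.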